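Changing the amine chain: allyl to isobutyl

The source may hold more compounds than are shown below. What is called first, only, known or untested is meant among the compounds shown, and "the series" means these compounds.

compound 1 `CCCNC(=C\C(=O)/C=C/c1ccc(O)c(OC)c1)/C=C/c1ccc(O)c(OC)c1` — in an ADME assay on Caco-2 cells (Homo sapiens) for inhibition, read by MTT assay, with a stated time of 72 h (a higher number here means a weaker inhibitor, a lower number a stronger inhibitor), compound 1 gives > 25000 nM, a limit of the assay.
compound 2 `C=CCNC(=C\C(=O)/C=C/c1ccc(O)c(OC)c1)/C=C/c1ccc(O)c(OC)c1` — in this assay compound 2 gives > 25000 nM, a limit of the assay.

Compound 2 stands only at a limit in this assay, so no number is known for it. For the measured compounds named here, the one measured step, a step that the two limits leave unreadable from compound 1 to compound 2, cannot be read because both of its ends sit at the limit of > 25000 nM in this assay, at which 2 of the 2 values shown sit. Compound 3 `COc1cc(/C=C/C(=O)/C=C(/C=C/c2ccc(O)c(OC)c2)NCC(C)C)ccc1O` carries isopropyl in place of vinyl on a saturated chain carbon bound to an amine nitrogen. The same place was altered in that unreadable step, so nothing points to a change beyond the scatter in either direction. Compound 3 is therefore expected to sit at a limit as well, with an estimated 50000 nM and a range from 25000 nM to 200000 nM. This estimate for compound 3 means an expected step that the limit leaves unreadable from compound 2 to compound 3.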

Compound 3, half-maximal inhibitory concentration: > 25000 nM
Compound 3 gave a limit, no number (the forecaster's own chance of this, stated with the estimate: 85%); the middle value does not contradict the limit.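

Neither new step, from compound 2 to compound 3 or from compound 1 to compound 3, can be read, because all three compounds sit at the same limit: the limit of > 25000 nM in this assay, at which 3 of the 3 values shown sit.

The compounds shown leave open whether these three amine chains differ at all in this assay.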